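The source may hold more compounds than are shown below. What is called first, only, known or untested is meant among the compounds shown, and "the series" means these compounds.

For the measured compounds named here, compound 2 `COc1ccc(C2=NN(C3=NC(=O)/C(=C4\C(=O)Nc5ccc(Br)cc54)S3)C(c3ccc(Cl)cc3)C2)cc1` stands at the lowest of the two numbers so far measured in a functional assay on cells (Cancer cell lines, Homo sapiens) for cytotoxicity, read by sulforhodamine B assay, with a stated time of 48 h; a lower number here means a stronger inhibitor of growth, a higher number a weaker inhibitor of growth: compound 2 gives 14700 nM, while compound 1 `COc1ccc(C2=NN(C3=NC(=O)/C(=C4\C(=O)Nc5ccc(Cl)cc54)S3)C(c3ccc(OC)cc3)C2)cc1` gives 21200 nM, a gap that lies within the scatter. Compound 3 `COc1ccc(C2=NN(C3=NC(=O)/C(=C4\C(=O)Nc5ccc(Cl)cc54)S3)C(c3ccc(Cl)cc3)C2)cc1` differs from compound 2 in one place: chloro in place of bromo on an aromatic carbon. Going by the values given here, no step between measured compounds covers such an exchange, so the expectation rests on compound 2 alone. The step is expected to be small, in no clear direction and not beyond the scatter, estimated as a 1.1-fold higher number from compound 2 to compound 3 (0.04 log units; within the scatter). Compound 3 is therefore expected to give 16000 nM in this assay, within a range from 8000 nM to 32000 nM.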

Compound 3, concentration for total growth inhibition: 7970 nM
Beside the measured number, compound 3's estimate is 2.0-fold (0.30 log units) above it, and the stated range ends above it.
By their numbers in this assay, from the lowest: compounds 3, 2 and 1 (each within the scatter of the next, the first and the last beyond it).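

In this assay, chloro in place of bromo on the aromatic ring that is part of the fused system gives a 1.8-fold lower number from compound 2 to compound 3 (0.27 log units; within the scatter), so the two halogens are not told apart at this position. Chloro in place of methoxy on an aromatic carbon gives a 2.7-fold lower number from compound 1 to compound 3 (0.42 log units; beyond the scatter), a modest step that shows the other substituent matters more in this small set. Nothing given here explains either step.

The compounds shown leave open how an amine or a carboxylic acid would read at the bromo and chloro position. They also leave open whether the methoxy to chloro step holds with bromo in place.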